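Cytotoxicity of Two Urea Compounds and an Untested Analogue

The source may hold more compounds than are shown below. What is called first, only, known or untested is meant among the compounds shown, and "the series" means these compounds.

Measured compounds:
compound 1 `CSc1ccc(NC(=O)Nc2cc(C)nc3ccccc23)cc1` — 24000 nM
compound 2 `Cc1cc(NC(=O)Nc2cc(Cl)cc(Cl)c2)c2ccccc2n1` — > 25000 nM

Both measured compounds were tested in an ADME assay on HEK293 cells (Homo sapiens) for cytotoxicity, with a stated time of 72 h; a lower number here means that less compound is needed, a higher number that more compound is needed for the effect. Among the compounds with values here, compound 1 gives 24000 nM, which is the only actual number recorded in this assay. Compound 2 is reported as > 25000 nM, and this is a limit of the assay rather than a number. So compound 1 stands as the one measured value, with the limit of > 25000 nM in this assay, at which 1 of the 2 values shown sits, describing where compound 2 sits. Within the data shown here, no pair of measured compounds differs in a single place, so no measured step is available.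

The untested compound 3 `COc1ccc(NC(=O)Nc2cc(C)nc3ccccc23)cc1` differs from compound 1 in one place: methoxy in place of methylsulfanyl on an aromatic carbon. Compound 3 is expected to sit close to compound 1 in this assay, with a step of a 1.3-fold higher number from compound 1 to compound 3 (0.10 log units; within the scatter), which is not beyond the usual scatter. Compound 3 is therefore estimated at 30000 nM, within a range from 12000 nM to 70000 nM, and a report of only a limit would not be surprising.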

Compound 3, half-maximal effective concentration: > 25000 nM
Compound 3 ended at the assay's limit (the forecaster's own chance of this, stated with the estimate: 55%); the middle value lies beyond the limit too.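

Within the data shown here, exchanging methylsulfanyl for methoxy, on an aromatic carbon para to a large group, is the first single-place change that can be read in this assay, and it gives an at least 1.0-fold higher number from compound 1 to compound 3 (0.01 log units; that floor lies within the scatter). This step is only a floor, since the reading for compound 3 is a limit of the assay and not a number, so the real size of the change cannot be told, and nothing here shows that the methoxy compound needs less compound for the effect than the methylsulfanyl compound. The reading at this limit is now the most common one among the compounds shown: the limit of > 25000 nM in this assay, at which 2 of the 3 values shown sit.

From the compounds shown here alone, only methylsulfanyl and methoxy are seen at this position, so it remains open whether another group there, such as an amine, a carboxylic acid or a longer chain like butoxy, would bring the number clearly down or leave it at the limit. Going by these compounds, it also remains open how far past the limit compound 3 really lies, and so whether the two groups truly differ in this assay at all.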